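Replacing the sulfonyl arm of compound 1

This account rests on a few compounds, and the source may have more. Where it says the series, first, only, none or still open, it means among the compounds named here.

Within the data shown here, in a functional assay on DU-145 cells (Homo sapiens) for inhibition, read by trypan blue exclusion, with a stated time of 96 h (on this read-out lower numbers stand for stronger inhibition of growth and higher numbers for weaker inhibition of growth), compound 1 `Cc1ccc(CS(=O)(=O)/C(=C/c2ccccc2OCc2ccccc2)C(=O)c2ccc(Cl)cc2)cc1` gives 1000 nM, the lowest of the three numbers measured so far. Compound 2 `COc1ccccc1/C=C(\C(=O)c1ccc(Cl)cc1)S(=O)(=O)Cc1ccc(C)cc1` gives 10000 nM, and compound 3 `Cc1ccc(CS(=O)(=O)/C(=C/c2ccccc2Br)C(=O)c2ccc(Cl)cc2)cc1` gives 25000 nM.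

Compound 4 `O=C(/C(=C\c1ccccc1OCc1ccccc1)Sc1ccc(Br)cc1)c1ccc(Cl)cc1` keeps the benzyloxy group of compound 1 and differs elsewhere: (4-bromophenyl)sulfanyl in place of (4-methylbenzyl)sulfonyl on a double-bonded chain carbon bound to a carbonyl carbon and a double-bonded chain carbon. In words, this is (4-bromophenyl)sulfanyl in place of (4-methylbenzyl)sulfonyl on a double-bonded chain carbon bound to a carbonyl carbon and a double-bonded chain carbon.

All three measured steps leave the (4-methylbenzyl)sulfonyl group untouched. Hydrogen in place of phenyl gives a 10-fold higher number from compound 1 to compound 2 (1.00 log units; beyond the scatter), bromo in place of benzyloxy gives a 25-fold higher number from compound 1 to compound 3 (1.40 log units; beyond the scatter), and bromo in place of methoxy gives a 2.5-fold higher number from compound 2 to compound 3 (0.40 log units; beyond the scatter). Among the measured compounds shown here, no measurement yet covers the change at hand, so these steps indicate its likely size only loosely. Both measured steps away from compound 1 raise the number, the smaller being a 10-fold higher number from compound 1 to compound 2 (1.00 log units; beyond the scatter), so a modest rise is the more likely outcome here too. The expected step in this assay is a 5.0-fold higher number from compound 1 to compound 4 (0.70 log units; beyond the scatter). For compound 4 the estimated value is 5000 nM, with an expected range of 1000 nM to 25000 nM.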

Compound 4, concentration for 50% growth inhibition: 10000 nM
Estimate against measurement, compound 4: 2.0-fold (0.30 log units) below; the measured number falls inside the stated range.
By their numbers in this assay, from the lowest: compound 1; then compounds 2 and 4 (each within the scatter of the next); then compound 3.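

Until compound 4, every compound carried (4-methylbenzyl)sulfonyl, so nothing had been said about the double-bonded chain carbon bound to a carbonyl carbon and a double-bonded chain carbon; in this assay, (4-bromophenyl)sulfanyl in place of that group gives a 10-fold higher number from compound 1 to compound 4 (1.00 log units; beyond the scatter). The arm at this position therefore counts for the read-out: keeping the benzyloxy group, which the steps away from compound 1 had singled out, does not by itself keep the low number of compound 1. Nothing at hand explains the size of this step.

This single exchange alters the sulfur, the saturated carbon of the arm and the substituent on the arm's aromatic ring all at once, and the compounds shown leave open which of these changes accounts for the step. They also leave open how the number would respond to a (4-bromobenzyl)sulfonyl or (4-methylphenyl)sulfanyl arm, which would separate those changes, or to an arm carrying an amine or a carboxylic acid.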